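The source may hold more compounds than are shown below. What is called first, only, known or untested is meant among the compounds shown, and "the series" means these compounds.

Three compounds have been measured in an ADME assay on MT2 cells (Homo sapiens) for cytotoxicity, read by MTT assay; on this read-out lower numbers stand for higher toxicity in this test and higher numbers for lower toxicity in this test:

compound 1 `N#Cc1cc2c(Oc3ccc(F)cc3OCCn3ccc(=O)[nH]c3=O)cc(F)cn2c1`: 50000 nM
compound 2 `N#Cc1cc2c(Oc3ccc(F)cc3OCCn3ccc(=O)[nH]c3=O)cc(Cl)cn2c1`: 15000 nM
compound 3 `N#Cc1ccc2c(Oc3ccc(Cl)cc3OCCn3ccc(=O)[nH]c3=O)cc(Cl)cc2c1`: 20000 nM

Compound 2 and compound 1 differ in one place, (fluoro in place of chloro on an aromatic carbon), and this change gave a 3.3-fold higher number from compound 2 to compound 1 (0.52 log units; beyond the scatter), so compound 1 is the less toxic of the two in this test. Compound 3 rests on a different core; the difference between the two cores is not broken down here. Its value sits within the usual scatter of compound 2 and beyond the scatter of compound 1.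

Compound 4 `N#Cc1ccc2c(Oc3ccc(Cl)cc3OCCn3ccc(=O)[nH]c3=O)cc(F)cc2c1` has not yet been measured. Against compound 3 it shows (fluoro in place of chloro on an aromatic carbon). This is the same kind of change as that from compound 2 to compound 1, but the surroundings differ: in compound 1 the ring carrying the fluoro is a six-membered aromatic ring with 1 nitrogen, two atoms from the ring nitrogen, whereas in compound 4 it is a six-membered aromatic ring of carbon only.

Because compound 2 to compound 1 gave a 3.3-fold higher number from compound 2 to compound 1 (0.52 log units; beyond the scatter), a step of about a 2.5-fold higher number from compound 3 to compound 4 (0.40 log units; beyond the scatter) is expected here, tempered since the ring differs. Compound 4 is thus estimated at 50000 nM, between 20000 nM and 120000 nM.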

Compound 4, half-maximal cytotoxic concentration: 18000 nM
Compound 4: middle estimate off by 2.8-fold (0.44 log units), on the high side, and the stated range ends above it.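

In this assay, putting fluoro in place of chloro on the all-carbon ring gave a 1.1-fold lower number from compound 3 to compound 4 (0.05 log units; within the scatter), so compound 3 and compound 4 cannot be told apart in this test. The same swap on the nitrogen-containing ring had separated its pair, so its effect did not carry over from one core to the other: the same change on two cores in this assay, a 3.3-fold higher number (0.52 log units; beyond the scatter) from compound 2 to compound 1 and a 1.1-fold lower number (0.05 log units; within the scatter) from compound 3 to compound 4, 3.7-fold (0.57 log units) apart, beyond the scatter of two such steps. Among these compounds, this shows that the step seen on one core is a poor guide to the step on the other, but with only two pairs it does not show which difference between them matters, since the ring carrying the swap is not the only difference and the halogen on the other aromatic ring differs as well.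

The compounds shown leave open how other groups at this place, such as a methyl, a methoxy or a nitrile, would behave on either core. They also leave open whether a longer chain in these molecules would change these numbers.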